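Changing the group on sulfur and cytotoxicity in cells

The source may report more compounds than this note shows. Statements on the series, on what has been measured and on what is new or still open speak of the compounds shown alone.

Compound 1 `Cn1nc(-c2nnc(S)o2)cc1-c1ccc(C(F)(F)F)cc1`: in a functional assay on MCF7 cells (Homo sapiens) for cytotoxicity, read by MTT assay, with a stated time of 24 h (on this read-out lower numbers stand for stronger inhibition and higher numbers for weaker inhibition), compound 1 gives > 100000 nM, a limit of the assay.
Compound 2 `Cn1nc(-c2nnc(SCc3cccc(Cl)c3Cl)o2)cc1-c1ccc(C(F)(F)F)cc1`: in this assay compound 2 gives 32200 nM.
Compound 3 `Cn1nc(-c2nnc(SCc3ccc(C(F)(F)F)cc3)o2)cc1-c1ccc(C(F)(F)F)cc1`: in this assay compound 3 gives 15500 nM.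

Of the two numbers, compound 3 has the lowest; the step of a 2.1-fold lower number from compound 2 to compound 3 (0.32 log units; beyond the scatter) separates it from compound 2, and one value sits at a limit (the limit of > 100000 nM in this assay, at which 1 of the 3 values shown sits). Compound 4 `Cn1nc(-c2nnc(SCCc3ccc(F)cc3)o2)cc1-c1ccc(C(F)(F)F)cc1` differs from compound 3 by 4-fluorobenzyl in place of 4-(trifluoromethyl)phenyl on a saturated chain carbon bound to a sulfur. Going by the values given here, the steps of an at least 6.4-fold lower number from compound 1 to compound 3 (0.80 log units; beyond the scatter) and a 2.1-fold lower number from compound 2 to compound 3 (0.32 log units; beyond the scatter) bear on this change only in part: swapping the aryl group moved the number modestly, while no measured step alters the chain length. The author therefore expects a small step in this assay, probably toward a slightly higher number, a 1.4-fold higher number from compound 3 to compound 4 (0.15 log units; within the scatter). Compound 4 is estimated at 22000 nM, with a range from 7000 nM to 70000 nM.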

Compound 4, half-maximal inhibitory concentration: 25200 nM
Compound 4: middle estimate off by 1.1-fold (0.06 log units), on the low side, and the stated range covers the measured number.
By their numbers in this assay, from the lowest: compounds 3, 4 and 2 (each within the scatter of the next, the first and the last beyond it). At a limit, above all of these: compound 1.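

In this assay, 2-(4-fluorophenyl)ethyl on sulfur also improves on hydrogen, with an at least 3.9-fold lower number from compound 1 to compound 4 (0.59 log units; beyond the scatter), and this step rests on a limit: the limit of > 100000 nM in this assay, at which 1 of the 4 values shown sits.

Against the two benzyl compounds, the change gives a 1.6-fold higher number from compound 3 to compound 4 (0.21 log units; within the scatter) and a 1.3-fold lower number from compound 2 to compound 4 (0.11 log units; within the scatter). The position on sulfur thus accepts 2-(4-fluorophenyl)ethyl without a step beyond the scatter from either benzyl group.

Compound 4 changes the chain and the ring substituent at once, and the two cannot be read apart here. From the compounds shown here alone, how a longer chain or a carboxylic acid on sulfur would behave remains open.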